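Chromone acrylamide series: anilide variation, L02 cell inhibition

The compounds below may be only part of what the source reports. "The series", "measured", "known", "first", "only" and "open" are said of these compounds alone.

Measured so far in a functional assay on L02 cells (Homo sapiens) for inhibition, read by MTT assay, with a stated time of 48 h; on this read-out lower numbers stand for stronger inhibition and higher numbers for weaker inhibition:
- compound 1 `COc1ccc2c(=O)c(/C=C/C(=O)Nc3cc(C)ccc3C)coc2c1` gives > 200000 nM, which is a limit of the assay.
- compound 2 `COc1ccc2c(=O)c(/C=C/C(=O)Nc3ccc(Cl)cc3)coc2c1` gives > 200000 nM, again a limit.
- compound 3 `COc1ccc2c(=O)c(/C=C/C(=O)Nc3ccccc3C)coc2c1` gives > 200000 nM, again a limit.

Compound 1 stands only at a limit in this assay, with no number of its own; the other two values shown are limits as well, so that the limit of > 200000 nM in this assay, at which 3 of the 3 values shown sit, describes the whole measured set. The steps among the measured compounds are therefore not readable: a step that the two limits leave unreadable from compound 1 to compound 2, a step that the two limits leave unreadable from compound 1 to compound 3 and a step that the two limits leave unreadable from compound 2 to compound 3 all fall between two limits and give no size and no direction.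

Compound 4 `COc1ccc2c(=O)c(/C=C/C(=O)Nc3ccccc3Cl)coc2c1` differs from compound 1 by 2-chlorophenyl in place of 2,5-dimethylphenyl on an amide-type nitrogen. All three measured steps bear on this change in the sense that each of them exchanges one anilide for another, and none of them moved any value off the limit. No step beyond the scatter is therefore expected in this assay, and compound 4 is estimated to sit at the same limit, so that a step that the limit leaves unreadable from compound 1 to compound 4 is expected to be unreadable as well. The estimate for compound 4 is 250000 nM, within 100000 nM to 600000 nM, most likely reported only as a limit.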

Compound 4, half-maximal inhibitory concentration: > 200000 nM
Compound 4: no number, only a limit; the forecaster's own chance of this, stated with the estimate: 85%; the middle value does not contradict the limit.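

In this assay compound 4 gives > 200000 nM, which is a limit. The steps linking compound 4 with compound 1, compound 2 and compound 3 cannot be read, and the whole set stays at one limit: the limit of > 200000 nM in this assay, at which 4 of the 4 values shown sit. The compounds shown leave open whether any anilide of this series reaches a measurable value in this assay.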